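Thiophene in place of chlorophenyl on the thiosemicarbazone

A few compounds are considered here, and "the series" means these few. Any claim that something is new, unique, unknown or untested is made for them only; others in the source may bear on it.

Compounds measured in a functional assay on OVCAR-3 cells (Homo sapiens) for inhibition, read by sulforhodamine B assay, with a stated time of 48 h; on this read-out lower numbers stand for stronger inhibition of growth and higher numbers for weaker inhibition of growth: compound 1 `CC1=CC[C@H](C(C)(C)NC(=S)N/N=C/c2ccccc2Cl)CC1` gives 83600 nM; compound 2 `CC1=CC[C@H](C(C)(C)NC(=S)N/N=C/c2cccc(Cl)c2)CC1` gives 80500 nM; compound 3 `CC1=CC[C@H](C(C)(C)NC(=S)N/N=C/c2ccc(Cl)cc2)CC1` gives 26400 nM.

Compound 3 stands lowest of the three in this assay, beyond the scatter from both others: a 3.2-fold lower number from compound 1 to compound 3 (0.50 log units; beyond the scatter) and a 3.0-fold lower number from compound 2 to compound 3 (0.48 log units; beyond the scatter), while a 1.0-fold lower number from compound 1 to compound 2 (0.02 log units; within the scatter). Compound 4 `CC1=CC[C@H](C(C)(C)NC(=S)N/N=C/c2cccs2)CC1` differs from compound 3 by thiophen-2-yl in place of 4-chlorophenyl on a carbon with a double bond to nitrogen. Among the measured compounds shown here, none of the measured steps bears directly on this change; all three only move a chlorine around a phenyl ring, and only the 4-chlorophenyl gave a modestly lower number. Because compound 3 owes its standing to a 3.0-fold lower number from compound 2 to compound 3 (0.48 log units; beyond the scatter) and the thiophene carries no chlorine, compound 4 is expected to sit somewhat higher in this assay, a step of a 2.1-fold higher number from compound 3 to compound 4 (0.32 log units; beyond the scatter). The estimate for compound 4 is 55000 nM, within 20000 nM to 150000 nM.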

Compound 4, concentration for total growth inhibition: 35100 nM
Compound 4: the middle estimate sits 1.6-fold (0.20 log units) above what was measured, within the range that was stated.
By their numbers in this assay, from the lowest: compounds 3 and 4 (each within the scatter of the next); then compounds 2 and 1 (each within the scatter of the next).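

In this assay, a chlorine on a phenyl ring is not required at this place for a number in the range of compound 3: thiophen-2-yl in place of 4-chlorophenyl stays within the scatter (a 1.3-fold higher number from compound 3 to compound 4 (0.12 log units; within the scatter)). The thiophene also stands apart from the two other chlorophenyl compounds (a 2.3-fold lower number from compound 2 to compound 4 (0.36 log units; beyond the scatter); a 2.4-fold lower number from compound 1 to compound 4 (0.38 log units; beyond the scatter)). Nothing available explains this result.

On these data alone, whether a pyridine ring, or an amine or carboxylic acid on the phenyl ring, would stay in the range of compounds 3 and 4 remains open.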